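This account rests on a few compounds, and the source may have more. Where it says the series, first, only, none or still open, it means among the compounds named here.

In a functional assay on KB cells (Homo sapiens) for inhibition, read by sulforhodamine B assay (on this read-out higher numbers stand for weaker inhibition of growth and lower numbers for stronger inhibition of growth), compound 1 `Cc1ccc2[nH]c(-c3ccc(-c4ccc(-c5ccc(N(C)C)cc5)cc4)cc3)nc2c1` gives 6240 nM. Compound 3 `CN(C)c1ccc(-c2ccc(-c3ccc(-c4nc5c(O)cccc5[nH]4)cc3)cc2)cc1` gives 4200 nM, which is a 1.5-fold lower number from compound 1 to compound 3 (0.17 log units; within the scatter). Compound 2 `CN(C)c1ccc(-c2ccc(-c3ccc(-c4nc5ccccc5[nH]4)cc3)cc2)cc1` gives 39300 nM, which is a 6.3-fold higher number from compound 1 to compound 2 (0.80 log units; beyond the scatter). So compound 1 stands level with compound 3, and only compound 2 stands apart. Compound 4 `Cc1ccc2[nH]c(-c3ccc(-c4ccc(-c5ccc(F)cc5)cc4)cc3)nc2c1` differs from compound 1 by fluoro in place of dimethylamino on an aromatic carbon, with fluoro in place of dimethylamino on an aromatic carbon. Among the compounds with values here, all three measured compounds carry dimethylamino, so no measured step replaces it. The other measured step is a 9.4-fold lower number from compound 2 to compound 3 (0.97 log units; beyond the scatter). Such steps show that one small change can move this assay noticeably, but they give no direction for this change. The expected result is therefore a 1.0-fold lower number from compound 1 to compound 4 (0.02 log units; within the scatter), with a wide margin either way. For compound 4 the estimated value is 6000 nM, with an expected range of 1500 nM to 25000 nM.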

Compound 4, concentration for 50% growth inhibition: 24900 nM
The estimate for compound 4 lay 4.2-fold (0.62 log units) below the measured number; the measured number falls inside the stated range.
By their numbers in this assay, from the lowest: compounds 3 and 1 (each within the scatter of the next); then compounds 4 and 2 (each within the scatter of the next).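

Replacing dimethylamino with fluoro, para to a large group, gives a 4.0-fold higher number from compound 1 to compound 4 (0.60 log units; beyond the scatter) in this assay, so this position does affect growth inhibition, and of these two groups dimethylamino gives the stronger inhibition. All earlier steps kept dimethylamino in place, so this is the first change shown at this position. No measurement shown explains the difference. From the compounds shown here alone, whether a primary amine, a methoxy group or a carboxylic acid here would match dimethylamino or fluoro remains open. So does whether fluoro would have the same effect in compound 2 or compound 3.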